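From Methylthiazole Amide to Benzothiazole Amide: an Expected Step

The source may report more compounds than this note shows. Statements on the series, on what has been measured and on what is new or still open speak of the compounds shown alone.

Compound 1 `Cc1cnc(NC(=O)COc2ccc(/C=C3\SC(=O)NC3=O)cc2)s1` is known in a functional assay on MCF7 cells (Homo sapiens) for cytotoxicity, read by sulforhodamine B assay, with a stated time of 48 h (a lower number here means a stronger inhibitor of growth, a higher number a weaker inhibitor of growth), only as a limit, < 100000 nM. In this assay compound 2 `O=C(COc1ccc(/C=C2\SC(=O)NC2=O)cc1)Nc1cccc(C(F)(F)F)c1` gives 30200 nM; 195 nM (2 entries), and the several entries of compound 2 in this assay, 30200 nM; 195 nM (2 entries) shows how widely repeated readings of this kind can scatter. Compound 3 `O=C(COc1ccc(/C=C2\SC(=O)NC2=O)cc1)Nc1nc2ccccc2s1` carries 1,3-benzothiazol-2-yl in place of 5-methyl-1,3-thiazol-2-yl on an amide-type nitrogen. Among the measured compounds shown here, no measured step joins compound 1 to another compound, so the effect of this change has no measured precedent here. The step from compound 1 to compound 3 is expected to be modest, a step that the limit leaves unreadable from compound 1 to compound 3, not beyond the scatter. For compound 3 the estimated value in this assay is 20000 nM, with a range from 2000 nM to 100000 nM.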

Compound 3, concentration for 50% growth inhibition: 25100 nM
Compound 3: the middle estimate sits 1.3-fold (0.10 log units) below what was measured; low and high end bracket the measured number.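

Among the compounds shown here, compound 1 stands in this assay only as the limit < 100000 nM and so no step to compound 3 can be read. The compounds shown leave open how 1,3-benzothiazol-2-yl compares with 5-methyl-1,3-thiazol-2-yl on growth inhibition.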